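The source may hold more compounds than are shown below. What is called first, only, known or untested is meant among the compounds shown, and "the series" means these compounds.

In a functional assay on the whole organism for inhibition, with Rattus norvegicus as the target (on this read-out lower numbers stand for an effect already at smaller amounts and higher numbers for an effect only at larger amounts of compound), compound 1 `Cc1cccc(CC(C)(Oc2ccc(C(C)C)cc2)C(=O)O)c1` gives < 1 mg/kg, which is a limit of the assay and not a number. Two relatives offer firmer readings: compound 2 `CCc1ccccc1CC(C)(Oc1ccc(C(C)C)cc1)C(=O)O` gives 5 mg/kg, and compound 3 `CCc1ccc(CC(C)(Oc2ccc(C(C)C)cc2)C(=O)O)cc1` gives 0.1 mg/kg.

Compound 4 `CC(C)c1ccc(OC(C)(Cc2cccc(-c3ccccc3)c2)C(=O)O)cc1` keeps the core of compound 1 but has phenyl in place of methyl on an aromatic carbon, meta to a large group: phenyl in place of methyl on an aromatic carbon.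

Among the compounds with values here, no measured step makes this exact change. The nearest evidence comes from changes to the same aromatic ring, which gave an at least 5.0-fold higher number from compound 1 to compound 2 (0.69 log units; beyond the scatter) and a 50-fold lower number from compound 2 to compound 3 (1.70 log units; beyond the scatter). These show that this assay can respond strongly to such edits, in either direction. Compound 2, at 5 mg/kg, shows the cost that a changed ring can carry, so a moderately higher number is expected here, with wide uncertainty.

The expected step is an at least 1.5-fold higher number from compound 1 to compound 4 (0.17 log units; that floor lies within the scatter), and it is only approximate since its starting point is a limit. Compound 4 is estimated at 1.5 mg/kg, with an expected range from 0.2 mg/kg to 10 mg/kg.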

Compound 4, dose for half-maximal effect: 0.5 mg/kg
Compound 4: the middle estimate sits 3.0-fold (0.48 log units) above what was measured, within the range that was stated.
By their numbers in this assay, from the lowest: compound 3; then compound 4; then compound 2.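

No new step can be read between compound 1 and compound 4, because compound 1 is known only through a limit of the assay: the limit of < 1 mg/kg in this assay, at which 1 of the 4 values shown sits.

The compounds shown leave open how far phenyl in place of methyl on an aromatic carbon actually shifts the dose needed in this assay.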